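Bromo to Acetyl in a Three-Compound Series

The source may hold more compounds than are shown below. What is called first, only, known or untested is meant among the compounds shown, and "the series" means these compounds.

Compound 1 `COc1ccc(Nc2nnc(Cl)c(Nc3cc(OC)c(OC)c(OC)c3)n2)cc1`: 22300 nM
Compound 2 `COc1cc(Nc2nc(Nc3ccc(C)cc3)nnc2Cl)cc(OC)c1OC`: 27300 nM
Compound 3 `COc1cc(Nc2nc(Nc3ccc(Br)cc3)nnc2Cl)cc(OC)c1OC`: 41600 nM

In a functional assay on ECa-109 cells for inhibition, with ECa-109 cell line (Homo sapiens) as the target, read by MTT assay, with a stated time of 48 h (a higher number here means a weaker inhibitor, a lower number a stronger inhibitor), compound 3 gives 41600 nM, which lies within the scatter of the other two: a 1.9-fold higher number from compound 1 to compound 3 (0.27 log units; within the scatter), and a 1.5-fold higher number from compound 2 to compound 3 (0.18 log units; within the scatter). Compound 4 `COc1cc(Nc2nc(Nc3ccc(C(C)=O)cc3)nnc2Cl)cc(OC)c1OC` differs from it by one change, acetyl in place of bromo on an aromatic carbon, para to a large group. The remaining measured step at this place, a 1.2-fold higher number from compound 1 to compound 2 (0.09 log units; within the scatter), is also small. Among the measured compounds shown here, no measured compound carries acetyl, so the data point in no direction, and no step beyond the scatter is expected. The estimated step is a 1.4-fold lower number from compound 3 to compound 4 (0.14 log units; within the scatter). Compound 4 is estimated at 30000 nM, with an expected range of 12000 nM to 70000 nM.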

Compound 4, half-maximal inhibitory concentration: 36300 nM
Estimate against measurement, compound 4: 1.2-fold (0.08 log units) below; the measured number falls inside the stated range.
By their numbers in this assay, from the lowest: compounds 1, 2, 4 and 3 (each within the scatter of the next).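

At this place, para to a large group, acetyl joins methoxy, methyl and bromo with no step beyond the scatter in this assay: a 1.1-fold lower number from compound 3 to compound 4 (0.06 log units; within the scatter), a 1.3-fold higher number from compound 2 to compound 4 (0.12 log units; within the scatter) and a 1.6-fold higher number from compound 1 to compound 4 (0.21 log units; within the scatter). The larger group with its hydrogen-bond acceptor, which bromo lacks, therefore leaves the number within the scatter of all three earlier compounds. Nothing at hand bears on why these numbers stay so close.

The compounds shown leave open whether an amine, a carboxylic acid or a longer chain at this place would give a step beyond the scatter.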